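Aryl exchange from compound 3 to compound 4

The source may report more compounds than this note shows. Statements on the series, on what has been measured and on what is new or still open speak of the compounds shown alone.

For the measured compounds named here, in a functional assay on HT-29 cells (Homo sapiens) for antiproliferative activity, read by MTT assay, with a stated time of 72 h (on this read-out lower numbers stand for stronger inhibition and higher numbers for weaker inhibition), compound 1 `C=CC(=O)Nc1nc(-c2cccc(Cl)c2)cs1` gives 11000 nM, the only number so far. Compound 2 `C=CC(=O)Nc1nc(-c2ccccc2OC)cs1` reads > 30000 nM, which is a limit. Compound 3 `C=CC(=O)N(Cc1cc(C)no1)c1nc(-c2ccccc2OC)cs1` reads > 30000 nM, also a limit, so there is no number to start from. The floor of the readable range matters here: the limit of > 30000 nM in this assay, at which 2 of the 3 values shown sit. Going by the values given here, the one measured step, a step that the two limits leave unreadable from compound 2 to compound 3, offers no size to carry forward.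

Compound 4 `C=CC(=O)N(Cc1cc(C)no1)c1nc(-c2ccc(Cl)cc2O)cs1` has 4-chloro-2-hydroxyphenyl in place of 2-methoxyphenyl on an aromatic carbon of the shared core: 4-chloro-2-hydroxyphenyl in place of 2-methoxyphenyl on an aromatic carbon. The entering group carries a chlorine, as does the aryl group of compound 1, which gives 11000 nM but lacks the (3-methyl-1,2-oxazol-5-yl)methyl group of compound 3. On that single comparison, a shift toward stronger inhibition in this assay is expected, though another limit remains possible. The estimated change is an at least 2.3-fold lower number from compound 3 to compound 4 (0.36 log units; beyond the scatter). For compound 4 the expected value is 13000 nM, with an estimated range of 4000 nM to 30000 nM.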

Compound 4, half-maximal inhibitory concentration: > 30000 nM
Compound 4: only a limit was reported (the forecaster's own chance of this, stated with the estimate: 35%); middle value at least 2.3-fold (0.36 log units) away from the limit.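

Compound 3 and compound 4 both stand at a limit, so no step can be read between them, because the values collect at the end of the readable range: the limit of > 30000 nM in this assay, at which 3 of the 4 values shown sit.

The compounds shown leave open whether 4-chloro-2-hydroxyphenyl in place of 2-methoxyphenyl changes inhibition in this assay at all.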